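This account rests on a few compounds, and the source may have more. Where it says the series, first, only, none or still open, it means among the compounds named here.

In a functional assay on HCT-116 cells (Homo sapiens) for cytotoxicity, read by MTT assay, with a stated time of 72 h (a higher number here means a weaker inhibitor, a lower number a stronger inhibitor), compound 1 (`COc1ncc(-c2ccc3nc(NC(=O)N4CCCC4)nn3c2)cc1NS(=O)(=O)c1ccc(F)cc1`) gives 1290 nM while compound 2 (`COc1ncc(-c2ccc3nc(NC(=O)NC4CC4)nn3c2)cc1NS(=O)(=O)c1ccc(F)cc1`) gives 90 nM and compound 3 (`COc1ncc(-c2ccc3nc(NC(=O)NCCN4CCCCC4)nn3c2)cc1NS(=O)(=O)c1ccc(F)cc1`) gives 150 nM on the same core. Compound 2 thus stands within the scatter of compound 3, and both lie well apart from compound 1. Compound 4 (`COc1ncc(-c2ccc3nc(NC(=O)NCCN(C)C)nn3c2)cc1NS(=O)(=O)c1ccc(F)cc1`), not yet measured, differs from compound 2 by a single change (2-(dimethylamino)ethyl in place of cyclopropyl on an amide-type nitrogen) that puts 2-(dimethylamino)ethyl in place of cyclopropyl on an amide-type nitrogen. The closest guide is the step with compound 3 (a 1.7-fold higher number from compound 2 to compound 3 (0.22 log units; within the scatter)) which also replaces cyclopropyl on that nitrogen, there with 2-(piperidin-1-yl)ethyl, and stays within the scatter. The two larger steps (a 14-fold lower number from compound 1 to compound 2 (1.16 log units; beyond the scatter)) and (an 8.6-fold lower number from compound 1 to compound 3 (0.93 log units; beyond the scatter)) both replace pyrrolidin-1-yl on a carbonyl carbon, a different change, so they bear on it only weakly. No step beyond the scatter is therefore expected in this assay, and the expected step (a 1.4-fold higher number from compound 2 to compound 4 (0.16 log units; within the scatter)) is small. Compound 4 is estimated at 130 nM with an expected range from 50 nM to 350 nM for repeated measurements.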

Compound 4, half-maximal inhibitory concentration: 220 nM
Compound 4: middle estimate off by 1.7-fold (0.23 log units), on the low side; low and high end bracket the measured number.
By their numbers in this assay, from the lowest: compounds 2, 3 and 4 (each within the scatter of the next, the first and the last beyond it); then compound 1.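

In this assay, the change on the amide-type nitrogen gives a 2.4-fold higher number from compound 2 to compound 4 (0.39 log units; beyond the scatter), so replacing cyclopropyl with an open chain ending in an amine can move the number past the scatter, which the step to compound 3 did not do. The two chains themselves are not told apart, as a 1.5-fold higher number from compound 3 to compound 4 (0.17 log units; within the scatter) shows, while a 5.9-fold lower number from compound 1 to compound 4 (0.77 log units; beyond the scatter) places (2-(dimethylamino)ethyl)amino with cyclopropylamino and (2-(piperidin-1-yl)ethyl)amino, all well clear of pyrrolidin-1-yl on the carbonyl carbon. Nothing at hand accounts for these differences.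

The compounds shown leave open whether a plain ethyl group, a longer chain ending in dimethylamino or a morpholin-4-yl end group would stay near compound 2 or drift toward compound 1. They also leave open whether a methyl group on that amide-type nitrogen, replacing the amide hydrogen, would bring a cyclopropyl compound close to compound 1.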